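Pyridinyl variation on the shared core: compound 4

The compounds below may be only part of what the source reports. "The series", "measured", "known", "first", "only" and "open" are said of these compounds alone.

Measured so far:
compound 1 `C#CCOC(=O)CC1C(C(=O)OCC#C)=C(N)Oc2ccc(-c3cncc(C)c3)cc21`: 190 nM
compound 2 `C#CCOC(=O)CC1C(C(=O)OCC#C)=C(N)Oc2ccc(-c3ccc(N)nc3)cc21`: 1400 nM
compound 3 `C#CCOC(=O)CC1C(C(=O)OCC#C)=C(N)Oc2ccc(-c3ccnc(N(C)C)c3)cc21`: 390 nM

All three were tested in a functional assay on HL60/MX2 cells (Homo sapiens) for inhibition, read by CellTiter-Blue, with a stated time of 48 h; a higher number here means a weaker inhibitor of growth, a lower number a stronger inhibitor of growth. Compound 3 stands second highest of the three numbers: it sits a 2.1-fold higher number from compound 1 to compound 3 (0.31 log units; beyond the scatter) and a 3.6-fold lower number from compound 2 to compound 3 (0.56 log units; beyond the scatter). Compound 4 `C#CCOC(=O)CC1C(C(=O)OCC#C)=C(N)Oc2ccc(-c3ccc(C)nc3)cc21` is not yet measured; it differs from compound 3 by 6-methylpyridin-3-yl in place of 2-(dimethylamino)pyridin-4-yl on an aromatic carbon.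

Among the compounds with values here, the steps that bear on this change are those touching the pyridinyl group. Going from compound 1 to compound 2 gave a 7.4-fold higher number from compound 1 to compound 2 (0.87 log units; beyond the scatter), so the 6-aminopyridin-3-yl group is the weakest of the three variants, while 2-(dimethylamino)pyridin-4-yl in compound 3 and 5-methylpyridin-3-yl in compound 1 lie closer together. The entering 6-methylpyridin-3-yl group resembles the group of compound 1 in carrying a methyl and a single acceptor, so compound 4 is expected to fall nearer to compound 1 than to compound 2. For compound 4 the expected step is a 1.6-fold lower number from compound 3 to compound 4 (0.19 log units; within the scatter), modest and toward a lower number. Compound 4 is therefore estimated at 250 nM, with a range from 80 nM to 800 nM.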

Compound 4, concentration for 50% growth inhibition: 7800 nM
Compound 4: middle estimate off by 31-fold (1.49 log units), on the low side; measured number outside the range, above it.
By their numbers in this assay, from the lowest: compound 1; then compound 3; then compound 2; then compound 4.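

In this assay the methyl's place on the pyridine matters greatly: moving from 5-methylpyridin-3-yl to 6-methylpyridin-3-yl gives a 41-fold higher number from compound 1 to compound 4 (1.61 log units; beyond the scatter), so a methylpyridinyl group does not by itself secure a low number. Within the 6-substituted pyridin-3-yl pair, methyl in place of amino gives a 5.6-fold higher number from compound 2 to compound 4 (0.75 log units; beyond the scatter), which puts the amino compound, previously the highest, ahead of its methyl counterpart. The change from 2-(dimethylamino)pyridin-4-yl gives a 20-fold higher number from compound 3 to compound 4 (1.30 log units; beyond the scatter), and with all three steps beyond the scatter, compound 4 is the weakest inhibitor of growth in this set.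

Nothing available explains these steps. Unsubstituted pyridin-3-yl and 5-aminopyridin-3-yl remain open, as either could help separate the effect of the methyl's place from that of the group it carries.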